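Stilbene Analogs: From Methyl to Isopropyl

The compounds below may be only part of what the source reports. "The series", "measured", "known", "first", "only" and "open" are said of these compounds alone.

Compound 1 `COc1cccc(/C=C/c2ccccc2)c1OC` gives 4700 nM in an assay on HepG2 cells for activation of nuclear factor erythroid 2-related factor 2 (Homo sapiens), read by a luciferase reporter, with a stated time of 5 h; on this read-out lower numbers stand for an effect already at smaller amounts and higher numbers for an effect only at larger amounts of compound.
Compound 2 `COc1ccc(/C=C/c2cccc(O)c2)cc1` reaches only the assay's limit of > 15000 nM in this assay.
Compound 3 `COc1cccc(/C=C/c2ccc(C)cc2)c1OC` gives 1100 nM in this assay.

Among the numbers shown, compound 3 has the lowest; its nearest neighbour is compound 1, and the step of a 4.3-fold lower number from compound 1 to compound 3 (0.63 log units; beyond the scatter) lies beyond the scatter. Compound 2 stands apart, because its result is a limit rather than a number (the limit of > 15000 nM in this assay, at which 1 of the 3 values shown sits).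

Compound 4 `COc1cccc(/C=C/c2ccc(C(C)C)cc2)c1OC` differs from compound 3 by one change: isopropyl in place of methyl on an aromatic carbon. Going by the values given here, no measured step swaps methyl for isopropyl, so the only guide is the methyl-for-hydrogen step a 4.3-fold lower number from compound 1 to compound 3 (0.63 log units; beyond the scatter), which was modest. Growing the same group further might continue in that direction, or might give nothing beyond the scatter; a larger shift in either direction has no support here. The expectation is therefore a small further lowering, a 1.6-fold lower number from compound 3 to compound 4 (0.20 log units; within the scatter), with wide uncertainty. Compound 4 is estimated at 700 nM, within a range from 250 nM to 2500 nM.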

Compound 4, half-maximal effective concentration: 2700 nM
Estimate against measurement, compound 4: 3.9-fold (0.59 log units) below; the measured number lies above the stated range.
By their numbers in this assay, from the lowest: compound 3; then compounds 4 and 1 (each within the scatter of the next). At a limit, above all of these: compound 2.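

Growing methyl to isopropyl on this aromatic carbon gives a 2.5-fold higher number from compound 3 to compound 4 (0.39 log units; beyond the scatter), so the gain seen with methyl does not continue with the group of more carbons. Measured against hydrogen, isopropyl gives a 1.7-fold lower number from compound 1 to compound 4 (0.24 log units; within the scatter), so in this assay the benefit of methyl is not kept. Among hydrogen, methyl and isopropyl at this place, only methyl stands clear of the other two, which makes this a peak at methyl among three groups rather than a steady trend.

Going by these compounds, whether an ethyl group, an amine or a carboxylic acid at this place would come closer to compound 3 or to compound 1 remains open. Nothing measured for these compounds speaks to why isopropyl and methyl differ here.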